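A few compounds are considered here, and "the series" means these few. Any claim that something is new, unique, unknown or untested is made for them only; others in the source may bear on it.

Compound 1 `C=CC1=C(C(=O)NC(C)(C)C)C(c2ccc(OC)cc2)OC1` carries a tert-butyl amide on the shared core. In a functional assay on A549 cells (Homo sapiens) for cytotoxicity, read by MTT assay, with a stated time of 24 h (on this read-out higher numbers stand for weaker inhibition and lower numbers for stronger inhibition), compound 1 gives only a limit, > 100000 nM. Compound 2 `C=CC1=C(C(=O)NCC(C)C)C(c2ccc(Cl)c(Cl)c2)OC1` likewise reaches only a limit in this assay, > 100000 nM. Compound 3 `C=CC1=C(C(=O)NC(C)(C)C)C(c2ccc(F)cc2)OC1` also sits at a limit, > 100000 nM. For the measured compounds named here, all three values therefore sit at the limit of > 100000 nM in this assay, at which 3 of the 3 values shown sit, and the only measured step, from compound 1 to compound 3 a step that the two limits leave unreadable from compound 1 to compound 3, cannot be read in size. Compound 4 `C=CC1=C(C(=O)NCCC)C(c2ccc(OC)cc2)OC1` differs from compound 1 by propyl in place of tert-butyl on an amide-type nitrogen. Going by the values given here, no measured step touches the amide substituent, so nothing here argues for a readable change. Compound 4 is therefore expected to remain at the limit, the step of a number no higher from compound 1 to compound 4 (the limit leaves the size open) being expected as none beyond the scatter. The estimate for compound 4 is 100000 nM, with a range from 50000 nM to 300000 nM.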

Compound 4, half-maximal inhibitory concentration: > 100000 nM
Compound 4 ended at the assay's limit (the forecaster's own chance of this, stated with the estimate: 85%); the middle value sits exactly at the limit.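

No new step can be read: compound 1 and compound 4 both stand at a limit in this assay, so the size of the step between them stays unreadable: the limit of > 100000 nM in this assay, at which 4 of the 4 values shown sit.

The compounds shown leave open which change on the shared core, if any, would give a readable value in this assay.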